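The source may report more compounds than this note shows. Statements on the series, on what has been measured and on what is new or still open speak of the compounds shown alone.

Working notes on the series. Compound 1 `Cc1nc2c3ccccc3ccc2c2nc3c(ccc4ccccc43)c(-c3nccnc3N)c12` and compound 2 `COc1ccc(-c2c3ccc4ccccc4c3nc3c2c(C)nc2c4ccccc4ccc32)cc1` share a core and differ only at one aromatic carbon. In a functional assay on AGS cells (Homo sapiens) for cytotoxicity, read by MTT assay, with a stated time of 48 h (on this read-out lower numbers stand for stronger inhibition and higher numbers for weaker inhibition), compound 1 gives 2260 nM, whereas compound 2 gives 66400 nM. Going by the values given here, the one measured step, a 29-fold higher number from compound 1 to compound 2 (1.47 log units; beyond the scatter), shows that the group at this position has a large effect on the read-out. Among the compounds with values here, on the numbers so far compound 2 stands at the highest value of the two, with compound 1 as its only neighbour at a much lower number.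

Compound 3 `Cc1nc2c3ccccc3ccc2c2nc3c(ccc4ccccc43)c(C)c12` is the next member, not yet measured. Against compound 2 the change is methyl in place of 4-methoxyphenyl on an aromatic carbon. Within the data shown here, no measured step covers the loss of the 4-methoxyphenyl to a methyl; the only step available concerns a different exchange at the same carbon and does not tell which way a methyl will go. With the 3-aminopyrazin-2-yl absent in both compound 2 and compound 3, no strong recovery toward compound 1 is expected. Compound 3 is therefore estimated at 40000 nM, with a range of 8000 nM to 200000 nM, a step of a 1.7-fold lower number from compound 2 to compound 3 (0.22 log units; within the scatter) that is expected to remain within or near the scatter.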

Compound 3, half-maximal inhibitory concentration: > 80000 nM
Compound 3 ended at the assay's limit (the forecaster's own chance of this, stated with the estimate: 25%); middle value at least 2.0-fold (0.30 log units) away from the limit.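

In this assay compound 3 gives > 80000 nM, which is a limit of the assay and not a number. With an at least 35-fold higher number from compound 1 to compound 3 (1.54 log units; beyond the scatter), methyl in place of 3-aminopyrazin-2-yl joins 4-methoxyphenyl as a second replacement at this aromatic carbon that leaves the number far higher, so among the three compounds the lowest number goes with the 3-aminopyrazin-2-yl alone. Between the two replacements, an at least 1.2-fold higher number from compound 2 to compound 3 (0.08 log units; that floor lies within the scatter) gives only a floor, so no order of methyl and 4-methoxyphenyl can be stated, and the true size of this step stays unread: the limit of > 80000 nM in this assay, at which 1 of the 3 values shown sits.

The compounds shown leave open whether the lower number goes with the amine or with the ring of the 3-aminopyrazin-2-yl, a question that a plain pyrazin-2-yl without the amine or an aminophenyl at the same carbon would address. They also leave open how a carboxylic acid or a longer chain would read at this carbon on the shared core.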